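This account rests on a few compounds, and the source may have more. Where it says the series, first, only, none or still open, it means among the compounds named here.

In a functional assay (strain AB) with Danio rerio as the target, read by microscopy, with a stated time of 1 h (a higher number here means that more compound is needed for the effect, a lower number that less compound is needed), compound 2 `CCN1CCc2c(sc(NC(=O)Nc3cccc(C#N)c3)c2C(N)=O)C1` gives 10300 nM and compound 1 `CCN1CCc2c(sc(NC(=O)Nc3cccc(C)c3)c2C(N)=O)C1` gives 13000 nM, so the two stand within the scatter of each other. Compound 3 `CCN1CCc2c(sc(NC(=O)Nc3ccc(I)cc3)c2C(N)=O)C1` is the next case, with 4-iodophenyl in place of 3-cyanophenyl on an amide-type nitrogen. Within the data shown here, the only measured step, a 1.3-fold lower number from compound 1 to compound 2 (0.10 log units; within the scatter), swaps methyl for cyano on an aromatic carbon. Among the measured compounds shown here, no measured compound carries iodine, so that step is thin support, and the range must stay wide. No shift beyond the scatter is expected in this assay, and the expected step is a 1.0-fold lower number from compound 2 to compound 3 (0.01 log units; within the scatter). Compound 3 is estimated at 10000 nM, with an expected range of 3500 nM to 28000 nM.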

Compound 3, half-maximal effective concentration: 1620 nM
Compound 3: the middle estimate sits 6.2-fold (0.79 log units) above what was measured; the measured number lies below the stated range.
By their numbers in this assay, from the lowest: compound 3; then compounds 2 and 1 (each within the scatter of the next).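

On the amide-type nitrogen, 4-iodophenyl gives a 6.4-fold lower number from compound 2 to compound 3 (0.80 log units; beyond the scatter) and an 8.0-fold lower number from compound 1 to compound 3 (0.90 log units; beyond the scatter) in this assay as steps beyond the scatter, whereas the swap of methyl for cyano had stayed within it. The aryl group at this position can therefore shift the number, so the flat picture from compound 1 and compound 2 does not hold for all groups here. The change replaces both the substituent and its place on the ring, and nothing available accounts for the shift.

On these data alone, whether the iodine or its place on the ring carries the step stays open. So does how a bromine, an amine or a carboxylic acid would stand in place of the iodine.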